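This account rests on a few compounds, and the source may have more. Where it says the series, first, only, none or still open, it means among the compounds named here.

Measured in a functional assay on MDA-MB-231 cells (Homo sapiens) for antiproliferative activity, with a stated time of 48 h; a lower number here means a stronger inhibitor, a higher number a weaker inhibitor:
compound 1 `CCN(CC)c1ccc(-c2cccc(OC)c2)nn1`: > 25000 nM
compound 2 `CCN(CC)c1ccc(-c2cccc(C#N)c2)nn1`: > 25000 nM
compound 3 `CCOC(=O)c1cccc(-c2ccc(N(CC)CC)nn2)c1`: > 25000 nM

Compound 2 stands at > 25000 nM, which is a limit of the assay and not a number. Among the measured compounds shown here, the two other compounds give limits as well, so the series so far sits at the limit of > 25000 nM in this assay, at which 3 of the 3 values shown sit, and no order can be drawn among the three.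

Compound 4 `CCCCOc1ccc(-c2cccc(C#N)c2)nn1` departs from compound 2 at one place, with butoxy in place of diethylamino on an aromatic carbon.

The measured steps are a step that the two limits leave unreadable from compound 1 to compound 2, a step that the two limits leave unreadable from compound 1 to compound 3 and a step that the two limits leave unreadable from compound 2 to compound 3. All three exchange methoxy, cyano and ethoxycarbonyl among themselves. None touches the diethylamino group and none has a readable size, so they give no measure for this change.

In this assay no large step is expected. If a number appears at all, the direction would be toward stronger inhibition, since compound 2 sits at > 25000 nM. A further limit remains the more likely outcome.

The expected change is an at least 1.2-fold lower number from compound 2 to compound 4 (0.09 log units; that floor lies within the scatter), and this is an estimate with little support.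

For compound 4 the estimated value is 20000 nM, with an expected range of 7000 nM to 40000 nM.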

Compound 4, half-maximal inhibitory concentration: > 25000 nM
Compound 4 ended at the assay's limit; the forecaster's own chance of this, stated with the estimate: 60%; middle value at least 1.2-fold (0.09 log units) from the limit.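

In this assay compound 4 gives > 25000 nM, a limit of the assay and not a number, so the exchange of diethylamino for butoxy from compound 2 to compound 4 has no readable size. The compounds shown leave open which structural change, if any, would give a measured number, as the series stays at one limit: the limit of > 25000 nM in this assay, at which 4 of the 4 values shown sit.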